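This account rests on a few compounds, and the source may have more. Where it says the series, first, only, none or still open, it means among the compounds named here.

Measured compounds in a functional assay (Cavia porcellus) for antagonist activity at Serotonin 3 (5-HT3) receptor (Homo sapiens); a higher number here means a weaker inhibitor, a lower number a stronger inhibitor:
Compound 1, `CSc1cccc(N2CCN(C3CN4CCC3CC4)C2=O)c1` — compound 1 gives 214 nM.
Compound 2, `O=C1N(c2cccc(Br)c2)CCN1C1CN2CCC1CC2` — compound 2 gives 38.3 nM.
Compound 3, `Cc1[nH]cnc1CN1CCN(c2cccc(Br)c2)C1=O` — compound 3 gives 10.4 nM.

Compound 3 stands lowest of the three numbers. Its nearest neighbour is compound 2, whose value lies beyond the scatter above it; compound 1 lies furthest, also beyond the scatter. Among the compounds with values here, compound 2 and compound 3 differ in the group on the shared core, and no single step is drawn between them, so only their two values speak.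

Compound 4, `Cc1[nH]cnc1CN1CCN(c2cccc(C(F)(F)F)c2)C1=O`, has not yet been measured. It differs from compound 3 in one place: trifluoromethyl in place of bromo on an aromatic carbon. Within the data shown here, the only measured step at this position is a 5.6-fold lower number from compound 1 to compound 2 (0.75 log units; beyond the scatter), which shows that the group on this aromatic carbon can move the number by a modest amount. Among the measured compounds shown here, no measured step compares trifluoromethyl with bromo, so the direction of the change in this assay is open, and a change of roughly that size in either sense would not be surprising. Compound 4 is therefore expected to give about 16 nM, within a range from 5 nM to 50 nM, which corresponds to an estimated step of a 1.5-fold higher number from compound 3 to compound 4 (0.19 log units; within the scatter).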

Compound 4, antagonist equilibrium constant: 68.5 nM
Estimate against measurement, compound 4: 4.3-fold (0.63 log units) below; measured number above the stated range.
By their numbers in this assay, from the lowest: compound 3; then compounds 2 and 4 (each within the scatter of the next); then compound 1.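

In this assay, trifluoromethyl in place of bromo gives a 6.6-fold higher number from compound 3 to compound 4 (0.82 log units; beyond the scatter), which settles the direction of this change for this pair, with the bromo compound holding the lower number. Together with a 5.6-fold lower number from compound 1 to compound 2 (0.75 log units; beyond the scatter), it shows that two different replacements on this aromatic carbon each move the number beyond the scatter, and that in both steps the bromo compound has the lower number, although the two steps carry different groups elsewhere on the molecule. Nothing measured here gives a reason for this rise.

As far as these compounds go, whether methylsulfanyl or trifluoromethyl would read the same way against bromo with the other group in place remains open. So does how a nitrile, a methoxy group or an amine on this aromatic carbon would compare with bromo.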